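The source may report more compounds than this note shows. Statements on the series, on what has been measured and on what is new or still open speak of the compounds shown alone.

In a functional assay on HEp-2 cells (Homo sapiens) for cytotoxicity, read by MTT assay, with a stated time of 72 h (on this read-out higher numbers stand for weaker inhibition and lower numbers for stronger inhibition), the measured compounds stand as follows. Compound 1 `O=c1cc(CSc2nc3ccccc3s2)oc2ccccc12` gives > 25000 nM, which is a limit of the assay and not a number. Compound 2 `O=c1cc(CSc2nc3ccccc3s2)oc2ccc(Cl)cc12` gives > 25000 nM, again a limit rather than a number. Compound 3 `Cc1nnc(SCc2cc(=O)c3cc(Cl)ccc3o2)o1` gives > 25000 nM, likewise a limit.

From compound 2 to compound 1 the change is hydrogen in place of chloro on an aromatic carbon; the step it made in this assay is a step that the two limits leave unreadable from compound 2 to compound 1, since both ends are limits. All three values sit at the limit of > 25000 nM in this assay, at which 3 of the 3 values shown sit. How the core of compound 2 differs from the core of compound 3 is not broken down here.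

Compound 4 `Cc1nnc(SCc2cc(=O)c3ccccc3o2)o1` has not yet been measured in this assay. It differs from compound 3 by hydrogen in place of chloro on an aromatic carbon, the same change as that from compound 2 to compound 1, at the same kind of place.

The step from compound 3 to compound 4 is expected to be a step that the limit leaves unreadable from compound 3 to compound 4, an expectation that rests on (the limit of > 25000 nM in this assay, at which 3 of the 3 values shown sit), where compound 3 and both other measured compounds sit, and on the step from compound 2 to compound 1 being unreadable. For compound 4 the estimate in this assay is 35000 nM, with an expected range from 12000 nM to 120000 nM.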

Compound 4, half-maximal inhibitory concentration: > 25000 nM
Compound 4: only a limit was reported; the forecaster's own chance of this, stated with the estimate: 80%; the middle value lies beyond the limit too.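

In this assay compound 4 gives > 25000 nM, which is a limit and not a number. The values of compound 3 and compound 4 are both limits, so the step between them cannot be read. The compounds shown leave open how strongly any of them acts in this assay, and whether hydrogen in place of chloro on an aromatic carbon changes anything there.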